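A bromine added to the indole: a small second halogen step

This account rests on a few compounds, and the source may have more. Where it says the series, first, only, none or still open, it means among the compounds named here.

Compound 2 `CO[C@@H]1[C@H](N(C)c2ncc(-c3c[nH]c4ccccc34)s2)C[C@H]2O[C@]1(C)n1c3ccccc3c3c4c(c5c6cc(Br)ccc6n2c5c31)C(=O)NC4` and compound 1 `CO[C@@H]1[C@H](N(C)c2ncc(-c3c[nH]c4ccccc34)s2)C[C@H]2O[C@]1(C)n1c3ccccc3c3c4c(c5c6cc(Cl)ccc6n2c5c31)C(=O)NC4` share one core and differ only in a halogen on an aromatic carbon. In a functional assay on MV4-11 cells (Homo sapiens) for antiproliferative activity, read by CellTiter-Glo, with a stated time of 72 h (on this read-out higher numbers stand for weaker inhibition and lower numbers for stronger inhibition), compound 1 gives 560 nM, and compound 2 gives 360 nM; the step of a 1.6-fold lower number from compound 1 to compound 2 (0.19 log units; within the scatter) is within the scatter, so the two numbers cannot be ordered. Compound 2 thus holds the lowest of the two numbers shown, with compound 1 its only neighbour and within the scatter of it. Compound 3 `CO[C@@H]1[C@H](N(C)c2ncc(-c3c[nH]c4ccc(Br)cc34)s2)C[C@H]2O[C@]1(C)n1c3ccccc3c3c4c(c5c6cc(Br)ccc6n2c5c31)C(=O)NC4` carries the change (bromo in place of hydrogen on an aromatic carbon), placing a bromine on the 1H-indol-3-yl group. Within the data shown here, no measured step touches this ring; the only halogen step seen, from chloro to bromo on the other ring, was small. Compound 3 is therefore expected to give a number close to that of compound 2, with the expected step of a 1.2-fold lower number from compound 2 to compound 3 (0.08 log units; within the scatter) of no clear direction, and its estimated value is 300 nM within a range from 120 nM to 900 nM.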

Compound 3, half-maximal inhibitory concentration: 390 nM
Compound 3: middle estimate off by 1.3-fold (0.11 log units), on the low side, and the stated range covers the measured number.
By their numbers in this assay, from the lowest: compounds 2, 3 and 1 (each within the scatter of the next).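

In this assay, the change from 1H-indol-3-yl to 5-bromo-1H-indol-3-yl gives a 1.1-fold higher number from compound 2 to compound 3 (0.03 log units; within the scatter), so the number does not move measurably when this ring takes a bromine. This is the first step shown on this ring, and it adds a heavy atom in place of hydrogen rather than exchanging one halogen for another; like the step on the other ring, a 1.6-fold lower number from compound 1 to compound 2 (0.19 log units; within the scatter), it stays within the scatter. Nothing measured alongside these numbers offers an explanation for this result.

The compounds shown leave open whether an amine, a methoxy group or a carboxylic acid on this same carbon would move the number beyond the scatter. They also leave open whether a bromine on another carbon of this ring would read the same.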